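Methoxy for methyl on the amide ring

The compounds below may be only part of what the source reports. "The series", "measured", "known", "first", "only" and "open" are said of these compounds alone.

Compound 1, `O=C(/C=C/c1cccc(NC(=O)c2ccccc2Cl)c1)c1nc2ccccc2[nH]1`, gives 3690 nM in a functional assay on 143B cells (Homo sapiens) for antiproliferative activity, read by MTT assay, with a stated time of 48 h; a lower number here means a stronger inhibitor, a higher number a weaker inhibitor.
Compound 2, `O=C(Nc1cccc(/C=C/C(=O)c2nc3ccccc3[nH]2)c1)c1ccc(Cl)cc1`, gives 7440 nM in this assay.
Compound 3, `Cc1cccc(C(=O)Nc2cccc(/C=C/C(=O)c3nc4ccccc4[nH]3)c2)c1`, gives 4880 nM in this assay.

Compound 3 has the second highest of these three numbers, but its steps to compound 1 and compound 2 both lie within the scatter, so the three cannot be told apart. Compound 4, `COc1cccc(C(=O)Nc2cccc(/C=C/C(=O)c3nc4ccccc4[nH]3)c2)c1`, has not been measured. It differs from compound 3 in one place: methoxy in place of methyl on an aromatic carbon. For the measured compounds named here, the steps that bear on this, each changing the group on the same ring, were a 2.0-fold higher number from compound 1 to compound 2 (0.30 log units; within the scatter), a 1.3-fold higher number from compound 1 to compound 3 (0.12 log units; within the scatter) and a 1.5-fold lower number from compound 2 to compound 3 (0.18 log units; within the scatter); none left the scatter. A step of a 1.1-fold lower number from compound 3 to compound 4 (0.04 log units; within the scatter) is therefore expected, meaning none beyond the scatter. Compound 4 is estimated at 4500 nM, with a range of 2000 nM to 10000 nM.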

Compound 4, half-maximal inhibitory concentration: 4610 nM
Beside the measured number, compound 4's estimate is 1.0-fold (0.01 log units) below it, and the stated range covers the measured number.
By their numbers in this assay, from the lowest: compounds 1, 4, 3 and 2 (each within the scatter of the next).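

Methoxy brings one hydrogen-bond acceptor that methyl lacks, yet this assay shows only a 1.1-fold lower number from compound 3 to compound 4 (0.02 log units; within the scatter) at this ring position. The comparisons with the chlorinated rings, a 1.6-fold lower number from compound 2 to compound 4 (0.21 log units; within the scatter) and a 1.2-fold higher number from compound 1 to compound 4 (0.10 log units; within the scatter), likewise show no readable difference, so none of these four substituted rings stands apart. No measurement shown explains this flat result.

As far as these compounds go, whether an amine, a carboxylic acid or a longer chain in place of the methoxy would move the number beyond the scatter remains open.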